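The source may report more compounds than this note shows. Statements on the series, on what has been measured and on what is new or still open speak of the compounds shown alone.

Measured so far in a functional assay on U-266 cells (Homo sapiens) for cytotoxicity, read by MTT assay, with a stated time of 72 h; a lower number here means a stronger inhibitor, a higher number a weaker inhibitor:
- compound 1 `COc1ccc(C(CC(=O)N[C@@H](CC(C)C)B(O)O)NC(=O)c2ccccc2)cc1` gives 2650 nM
- compound 2 `COc1ccc([C@H](CC(=O)N[C@@H](CC(C)C)B(O)O)NC(=O)c2ccccc2)cc1` gives 1280 nM

Compound 2 holds the lower of the two numbers. Going by the values given here, the sole difference is the fact that one of compounds 1 and 2 is drawn with a defined configuration and the other without, at the place where they differ and it goes with a 2.1-fold lower number from compound 1 to compound 2 (0.32 log units; beyond the scatter) as the only measured step, modest but beyond the scatter.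

Compound 3 `COc1ccc([C@@H](CC(=O)N[C@@H](CC(C)C)B(O)O)NC(=O)c2ccccc2)cc1` changes that same centre: the two compounds have the same atoms and bonds and differ only in configuration as drawn: 1 of 2 stereo elements differ; a stereocentre at a saturated chain carbon is drawn S in compound 2 and R in compound 3 and so a stereocentre at a saturated chain carbon is drawn S in compound 2 and R in compound 3. Among the compounds with values here, no measured step makes this exact change, so the expectation is indirect. If compound 1 is a mixture of both forms, which its drawing leaves open, its 2650 nM suggests that the R form adds little. In this assay the expected shift is therefore upward, to a weaker inhibitor, and larger than a 2.1-fold lower number from compound 1 to compound 2 (0.32 log units; beyond the scatter) suggests at first sight. The expected size is a 3.9-fold higher number from compound 2 to compound 3 (0.59 log units; beyond the scatter) as a rough estimate. For compound 3 the estimated value is 5000 nM with an expected range from 1900 nM to 20000 nM in this assay.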

Compound 3, half-maximal inhibitory concentration: 350 nM
Compound 3: middle estimate off by 14-fold (1.15 log units), on the high side; the measured number lies below the stated range.
By their numbers in this assay, from the lowest: compound 3; then compound 2; then compound 1.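

In this assay, going by these compounds alone, the earlier compounds could not show which configuration at this chain carbon gives the stronger inhibitor, and now the R form does, with a 3.7-fold lower number from compound 2 to compound 3 (0.56 log units; beyond the scatter). Compound 1, drawn without a configuration, has a higher number than both defined forms, with a 7.6-fold lower number from compound 1 to compound 3 (0.88 log units; beyond the scatter), so it does not fall between them as a plain mixture of the two would. The gain in potency over compound 2 comes with no change in atoms or bonds, so it can be tied to the drawn configuration alone: the fact that compounds 2 and 3 differ only in the configuration as drawn

From the compounds shown here alone, it remains open what compound 1 actually contains, since its drawing does not say. Going by these compounds, it is also open whether the R form keeps its lead when the rest of the molecule changes, for example with a carboxylic acid in place of the boronic acid.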